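The source may report more compounds than this note shows. Statements on the series, on what has been measured and on what is new or still open speak of the compounds shown alone.

Of the compounds shown here, two have been measured so far in a physicochemical assay for lipophilicity, at pH 7.4; a lower number here means a more polar compound, a higher number a more lipophilic compound. Compound 1, `CCS(=O)(=O)c1ccc(CN(CC(C)C)S(=O)(=O)c2ccc3c(c2)C(O)CC(C2CCOCC2)O3)nc1`, gives in this assay a reading of 1.42, the lower of the two numbers. Compound 2, `CCc1ccc(N(CC(C)C)S(=O)(=O)c2ccc3c(c2)CCC3OC2CCOCC2)cc1`, gives in this assay a reading of 4.96, which lies well above compound 1, beyond the usual scatter of such measurements. No single-change comparison between these two is available; they simply mark the two ends of what has been seen.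

The next compound, compound 3, `CC(C)CN(C1CCc2ccc(F)cc21)S(=O)(=O)c1ccc2c(c1)C(O)CC(C1CCOCC1)O2`, is derived from compound 1 by one change: 6-fluoro-2,3-dihydro-1H-inden-1-yl in place of (5-(ethylsulfonyl)pyridin-2-yl)methyl on a sulfonamide nitrogen. The group that leaves carries three hydrogen-bond acceptors, among them the sulfonyl and the ring nitrogen; the group that enters carries no hydrogen-bond acceptor at all, only a fluorine on its aromatic ring. The change is therefore expected to move the reading upward by a large amount, a number 2.58 log units higher from compound 1 to compound 3 (beyond the scatter), toward the region where compound 2 sits with its value of 4.96. Compound 3 is estimated to come out at 4, within a range from 3.3 to 4.7.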

Compound 3, distribution coefficient: 3.94
Compound 3: the middle estimate sits 0.06 log units above what was measured; low and high end bracket the measured number.
By their numbers in this assay, from the lowest: compound 1; then compound 3; then compound 2.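

In this assay, for the compounds shown here, the sulfonamide nitrogen proves to be a place where the choice of group matters a great deal: 6-fluoro-2,3-dihydro-1H-inden-1-yl in place of (5-(ethylsulfonyl)pyridin-2-yl)methyl gives a number 2.52 log units higher from compound 1 to compound 3 (beyond the scatter) and so provides the first comparison in this set that rests on one change. That one change is a large exchange, since a sulfonyl-bearing group with a ring containing a hetero atom leaves and a group of carbon rings carrying a fluorine enters, while the rest of compound 1 stays as it was. Nothing measured alongside these compounds explains the size of this step.

The exchange alters several features at once, so the compounds shown cannot divide the step among the ethylsulfonyl group, the ring nitrogen, the fluorine and the second carbon ring. Going by these compounds, it remains open where a plain benzyl group, a 2,3-dihydro-1H-inden-1-yl group without the fluorine, or a group carrying a dimethylamino substituent would fall on the same sulfonamide nitrogen, whether nearer to compound 1 or to compound 3.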